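This account rests on a few compounds, and the source may have more. Where it says the series, first, only, none or still open, it means among the compounds named here.

The study concerns sulfonamides built on a shared core that carries a substituted aryl group on the sulfonyl. Compound 1 `COc1cc(C)ccc1S(=O)(=O)N1CCC(N2CCC(C)CC2)CC1` bears a small aryl group. In a functional assay on DLD-1 cells (Homo sapiens) for antiproliferative activity, read by CellTiter-Glo, with a stated time of 72 h (a higher number here means a weaker inhibitor, a lower number a stronger inhibitor), compound 1 reaches only > 5000 nM, which is a limit of the assay and not a number. Compound 2 `COc1ccc(-c2cccc(S(=O)(=O)N3CCC(N4CCC(C)CC4)CC3)c2)cc1` bears a biaryl group instead. In this assay compound 2 gives 23 nM. Among the two results available, that of compound 2 is the only actual number, the other one sitting at the limit of > 5000 nM in this assay, at which 1 of the 2 values shown sits.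

Compound 3 `CC1CCN(C2CCN(S(=O)(=O)c3cccc(-c4ccccc4)c3)CC2)CC1` follows from compound 2 by a single change: hydrogen in place of methoxy on an aromatic carbon. Among the compounds with values here, no step between two measured compounds isolates this change, so the expectation rests on compound 2 alone, with the biaryl group kept in place. The removal of the methoxy is expected to cost a little potency, a step of a 2.2-fold higher number from compound 2 to compound 3 (0.34 log units; beyond the scatter) that is modest in size and close to the scatter of the measurement. Compound 3 is therefore expected to give 50 nM in this assay, with an estimated range from 15 nM to 200 nM.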

Compound 3, half-maximal inhibitory concentration: 2 nM
Estimate against measurement, compound 3: 25-fold (1.40 log units) above, and the stated range ends above it.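

In this assay, the change from 4-methoxyphenyl to phenyl gives a 12-fold lower number from compound 2 to compound 3 (1.06 log units; beyond the scatter), so the methoxy on this aromatic carbon, para to a large group, is not required for activity, and the compound with hydrogen there is the stronger inhibitor. Within the data shown here, this is the first comparison that isolates a single place; compound 1 and compound 2 differ in more than one place, so their results could not speak to this position on its own. The data shown offer no measurement that accounts for the size of this step.

On these data alone, only methoxy and hydrogen are compared at this position, so it remains open how a fluorine, a hydroxyl, an amine or a carboxylic acid would fare there, and whether the gain belongs to hydrogen specifically or to the absence of methoxy. As far as these compounds go, it also remains open whether the same change would give a step of similar size if the phenyl group were attached elsewhere on the aromatic ring that bears the sulfonyl, or if the rest of the shared core were altered.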